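A few compounds are considered here, and "the series" means these few. Any claim that something is new, unique, unknown or untested is made for them only; others in the source may bear on it.

Compound 1 `O=C1C(=O)N(Cc2ccc(F)cc2)c2ccc(S(=O)(=O)N3CCCC3)cc21` is the starting point of the series. In an assay on isolated protein for inhibition of Caspase-8 (Homo sapiens) (a higher number here means that more compound is needed for the effect, a lower number that less compound is needed), compound 1 gives > 5000 nM, and this is a limit of the measurement rather than a number. Compound 2 `O=C1C(=O)N(Cc2ccc(F)cc2)c2ccc(S(=O)(=O)N3CCC[C@H]3COc3cccc(F)c3)cc21` carries a (3-fluorophenoxy)methyl group in place of a hydrogen on a saturated ring carbon; in this assay compound 2 gives > 5000 nM, again a limit. Compound 3 `O=C1C(=O)N(Cc2ccc(F)cc2)c2ccc(S(=O)(=O)N3CCC[C@H]3COc3cc(F)cc(F)c3)cc21` carries a (3,5-difluorophenoxy)methyl group on that saturated ring carbon; in this assay compound 3 gives > 5000 nM, also a limit. The steps a step that the two limits leave unreadable from compound 1 to compound 2, a step that the two limits leave unreadable from compound 1 to compound 3 and a step that the two limits leave unreadable from compound 2 to compound 3 therefore cannot be sized because of the limit of > 5000 nM in this assay, at which 3 of the 3 values shown sit. Compound 4 `O=C1C(=O)N(Cc2ccc(F)cc2)c2ccc(S(=O)(=O)N3CCC[C@H]3COC3CCOCC3)cc21` differs from compound 1 by ((oxan-4-yl)oxy)methyl in place of hydrogen on a saturated ring carbon. The measured steps bear on this change only in that two other groups placed on the same saturated ring carbon left the limit where it was, so no step beyond the scatter can be read in either direction. Compound 4 is therefore expected at 8000 nM, with a range from 3000 nM to 30000 nM, and the step that the limit leaves unreadable from compound 1 to compound 4 is expected to stay unreadable in the same way.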

Compound 4, half-maximal effective concentration: > 5000 nM
Compound 4: only a limit was reported (the forecaster's own chance of this, stated with the estimate: 80%); the middle value does not contradict the limit.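

Compound 4 also gives only a limit in this assay, so its steps from compound 1, compound 2 and compound 3 cannot be read: the limit of > 5000 nM in this assay, at which 4 of the 4 values shown sit. The compounds shown leave open how much of any of the four is needed in this assay and whether a group on that saturated ring carbon changes this at all.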